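A few compounds are considered here, and "the series" means these few. Any claim that something is new, unique, unknown or untested is made for them only; others in the source may bear on it.

Measured compounds in the series:

Compound 1 `COc1ccccc1C(=O)Nc1ccc(C)c(C(=O)O)c1`: > 10000 nM
Compound 2 `COc1cccc(C(=O)Nc2cccc(C(=O)O)c2)c1`: 1040 nM
Compound 3 `CC(C)CCOc1ccc(C(=O)Nc2cccc(C(=O)O)c2)cc1`: 215 nM

All three were run in an assay on isolated protein for agonist activity at Bile acid receptor (Homo sapiens), read by TR-FRET, with a stated time of 3 h, in the absence of a further agent; a lower number here means that less compound is needed, a higher number that more compound is needed for the effect. Compound 1 reached only the limit of that assay, so its entry is a limit and not a number (the limit of > 10000 nM in this assay, at which 1 of the 3 values shown sits). Among the two numbers available, compound 3 stands lowest, and the nearest number is that of compound 2, which sits clearly higher; that gap lies beyond the usual scatter of the method. With only these points, no pattern beyond the three compounds is claimed.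

The next compound, compound 4 `O=C(O)c1cccc(NC(=O)c2ccc(-c3ccccc3)cc2)c1`, differs from compound 3 in one place: phenyl in place of isopentyloxy on an aromatic carbon. Among the compounds with values here, no measured pair shows this exact change, so the expectation rests on compound 3 alone and on the fact that the leaving and the entering group are of equal heavy-atom count. The step from compound 3 to compound 4 in this assay is expected to be small, with a modest move toward a higher number or none beyond the scatter, estimated as a 1.9-fold higher number from compound 3 to compound 4 (0.27 log units; within the scatter). Compound 4 is accordingly estimated at 400 nM in this assay, expected to fall between 100 nM and 1600 nM.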

Compound 4, half-maximal effective concentration: > 10000 nM
Compound 4: a limit, no number; the forecaster's own chance of this, stated with the estimate: 5%; middle value at least 25-fold (1.39 log units) away from the limit.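

Exchanging isopentyloxy for phenyl on an aromatic carbon, para to a large group, gives an at least 46-fold higher number from compound 3 to compound 4 (1.66 log units; beyond the scatter) and shows that this position does not tolerate every group of equal heavy-atom count. The heavy-atom count therefore does not by itself track the read-out across this pair; what changes is an open chain with its oxygen and hydrogen-bond acceptor giving way to a six-membered aromatic ring of carbon only. The entry for compound 4 in this assay is a limit and not a number, so the true size of the step stays unknown and only its lower bound can be read, and this limit is now shared within the series: the limit of > 10000 nM in this assay, at which 2 of the 4 values shown sit.

The compounds shown do not separate the loss of the oxygen from the arrival of the ring, and a phenoxy group or a plain pentyl chain at this place would pull those two apart. Also open, as far as these compounds go, is how the read-out responds to a longer or shorter alkoxy chain at this position, and whether a terminal amine on that chain would be accepted.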